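Working notes on the series toward compound 4

The source may hold more compounds than are shown below. What is called first, only, known or untested is meant among the compounds shown, and "the series" means these compounds.

Measured so far in a functional assay on A549 cells (Homo sapiens) for inhibition, read by MTT assay, with a stated time of 72 h, tested at 20 uM; on this read-out higher numbers stand for more inhibition at the one concentration tested (going by the name of the read-out) and lower numbers for less inhibition:
- compound 1 `c1ccc(CNc2ccc(Oc3ncnc4ccsc34)cc2)cc1` gives 30.6%
- compound 2 `c1ccc2c(c1)CCN(c1ccnc(Nc3ccc(Oc4ncnc5ccsc45)cc3)n1)C2` gives 54.9%
- compound 3 `CN(c1ccc(Oc2ncnc3ccsc23)cc1)c1nccc(N2CCc3ccccc3C2)n1` gives 69.9%

Compound 2 holds the second highest of the three numbers. Its nearest neighbour is compound 3, reached by the step of a number 15 percentage points higher from compound 2 to compound 3 (beyond the scatter), a modest rise beyond the scatter. Compound 1 lies furthest away, on the low side, with 30.6% in this assay.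

Compound 4 `c1cc(N2CCCCC2)nc(Nc2ccc(Oc3ncnc4ccsc34)cc2)n1` differs from compound 2 by piperidin-1-yl in place of 1,2,3,4-tetrahydroisoquinolin-2-yl on an aromatic carbon.

Going by the values given here, only one step has been measured, a number 15 percentage points higher from compound 2 to compound 3 (beyond the scatter), and it concerns methyl in place of hydrogen on a nitrogen on an aromatic ring; nothing measured touches the group that leaves or the group that enters here. Among the compounds with values here, no step therefore bears on the change, and the expectation rests on compound 2 alone. The step expected is a number 7.9 percentage points lower from compound 2 to compound 4 (within the scatter), which would not reach beyond the scatter. Compound 4 is expected to give 47% in this assay, with the estimate ranging from 30% to 64%.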

Compound 4, a percentage reported as inhibition, at one concentration (the size of the read-out at that concentration, not a potency): 59.9%
Estimate against measurement, compound 4: 12.9 percentage points below; the measured number falls inside the stated range.
By their numbers in this assay, from the lowest: compound 1; then compounds 2, 4 and 3 (each within the scatter of the next, the first and the last beyond it).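

In this assay, going by these compounds alone, piperidin-1-yl in place of 1,2,3,4-tetrahydroisoquinolin-2-yl gives a number 5 percentage points higher from compound 2 to compound 4 (within the scatter), the first measured change on this aromatic carbon. Within this pair, the six-membered aromatic ring of carbon only can be lost from the substituent without a shift beyond the scatter, so the number at this concentration does not depend on that ring here. The data offer no measured property that would account for this result.

As far as these compounds go, it remains open whether methyl in place of hydrogen on the nitrogen, the change behind a number 15 percentage points higher from compound 2 to compound 3 (beyond the scatter), would act in the same way with piperidin-1-yl present. The compounds shown also leave open how this carbon would respond to morpholin-4-yl, a primary amine or a carboxylic acid.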